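Isopropylphenyl positional swap in a glycoside cytotoxicity series

The compounds below may be only part of what the source reports. "The series", "measured", "known", "first", "only" and "open" are said of these compounds alone.

Three glycosides carrying aryl ethers on the sugar have been run in a functional assay on HeLa cells (Homo sapiens) for cytotoxicity, read by MTT assay, with a stated time of 48 h; a lower number here means that less compound is needed, a higher number that more compound is needed for the effect. Compound 1 `CO[C@@H]1O[C@H](COc2cccc(C(C)C)c2)[C@@H](O)[C@H](O)[C@H]1Oc1ccc(OC2CCCCC2)cc1` gives 39000 nM. Compound 2 `CO[C@@H]1O[C@H](COc2ccccc2C(C)C)[C@@H](O)[C@H](O)[C@H]1Oc1ccc(OC2CCCCC2)cc1` gives 42000 nM. Compound 3 `CO[C@H]1O[C@H](COc2ccc(-c3ccccc3)cc2)[C@@H](O)[C@H](O)[C@H]1Oc1cccc(C(C)C)c1` gives 35000 nM. All three numbers lie within the scatter of one another, so no ordering among them is claimed.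

Among the compounds with values here, the one counted step, from compound 1 to compound 2, is 2-isopropylphenyl in place of 3-isopropylphenyl on an oxygen on a saturated carbon, and it reads a 1.1-fold higher number from compound 1 to compound 2 (0.03 log units; within the scatter). The difference between the core of compound 1 and the core of compound 3 is not broken down here.

Compound 4 `CO[C@H]1O[C@H](COc2ccc(-c3ccccc3)cc2)[C@@H](O)[C@H](O)[C@H]1Oc1ccccc1C(C)C` has not yet been measured. It differs from compound 3 by 2-isopropylphenyl in place of 3-isopropylphenyl on an oxygen on a saturated carbon. Within the data shown here, this is the same kind of change as the one from compound 1 to compound 2, but not the same: in compound 1 the oxygen sits on a saturated carbon whose other neighbour is a saturated chain carbon, whereas in compound 3 the oxygen sits on a saturated carbon whose other neighbour is a saturated ring carbon.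

The expectation for the step from compound 3 to compound 4 rests on the step already seen, since from compound 1 to compound 2 the change gave a 1.1-fold higher number from compound 1 to compound 2 (0.03 log units; within the scatter); a step of about a 1.1-fold higher number from compound 3 to compound 4 (0.04 log units; within the scatter) is expected. On that basis compound 4 is estimated at 38000 nM in this assay, with a range from 20000 nM to 75000 nM.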

Compound 4, half-maximal effective concentration: 29000 nM
Compound 4: middle estimate off by 1.3-fold (0.12 log units), on the high side, and the stated range covers the measured number.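

In this assay, 2-isopropylphenyl in place of 3-isopropylphenyl on an oxygen on a saturated carbon reads a 1.2-fold lower number from compound 3 to compound 4 (0.08 log units; within the scatter) on the core of compound 3, so the swap gives no readable change on this core. Set beside the earlier step on the core of compound 1, the two results cannot be told apart: the same change on two cores in this assay, a 1.1-fold higher number (0.03 log units; within the scatter) from compound 1 to compound 2 and a 1.2-fold lower number (0.08 log units; within the scatter) from compound 3 to compound 4, 1.3-fold (0.11 log units) apart, within the scatter of two such steps. This supports only a narrow reading, that the swap is without a readable effect on both cores shown; the opposite directions of the two small steps are no reversal, and two cores do not show that the same would hold on other cores in the series.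

The compounds shown vary this place only between two isopropylphenyl isomers, so it stays open whether a carboxylic acid or an amine on that phenyl ring, or a longer chain in place of isopropyl, would move the number in this assay beyond the scatter. The parts of the core of compound 1 and the core of compound 3 that differ also remain unresolved, since those compounds differ in more than one place and no single change between them can be read.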